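The compounds below may be only part of what the source reports. "The series", "measured", "known", "first", "only" and "open" are said of these compounds alone.

Measured compounds in this set:
- compound 1 `Cc1cccc(NC(=O)CSC(=S)N[C@H]2CCOC2=O)c1`: 63200 nM
- compound 2 `O=C(CSC(=S)N[C@H]1CCOC1=O)Nc1ccccc1`: > 128000 nM
- compound 3 `COc1ccc(NC(=O)CSC(=S)N[C@H]2CCOC2=O)cc1`: > 128000 nM

All three share one core and differ only in a single group on the aromatic ring. In a functional assay on MCF7 cells (Homo sapiens) for cytotoxicity, read by MTT assay, with a stated time of 72 h (on this read-out lower numbers stand for stronger inhibition and higher numbers for weaker inhibition), compound 1 gives 63200 nM. For compound 2 the value > 128000 nM is a limit of the assay, not a number. For compound 3 the value > 128000 nM is likewise a limit. Compound 3 therefore stands at the limit of > 128000 nM in this assay, at which 2 of the 3 values shown sit.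

Among the measured compounds shown here, two measured steps bear on the change ahead. The step of an at least 2.0-fold higher number from compound 1 to compound 2 (0.30 log units; that floor lies within the scatter), hydrogen in place of methyl on an aromatic carbon, only reaches the limit. The step that the two limits leave unreadable from compound 2 to compound 3, methoxy in place of hydrogen on an aromatic carbon, runs from one limit to another. Compound 4 `O=C(CSC(=S)N[C@H]1CCOC1=O)Nc1ccc(F)cc1` arises from compound 3 by fluoro in place of methoxy on an aromatic carbon. Neither earlier step gives a readable size, so no direction can be drawn from them. Compound 4 is expected to give about 128000 nM in this assay, with a range from 40000 nM to 400000 nM, which is an estimated step of a number no higher from compound 3 to compound 4 (the limit leaves the size open) and most likely again only a limit.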

Compound 4, half-maximal inhibitory concentration: 5830 nM
Estimate against measurement, compound 4: 22-fold (1.34 log units) above, outside the stated range (below it).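

In this assay, the position para to a large group on the aromatic ring now gives its first readable result: fluoro in place of methoxy gives an at least 21-fold lower number from compound 3 to compound 4 (1.34 log units; beyond the scatter), and fluoro in place of hydrogen gives an at least 21-fold lower number from compound 2 to compound 4 (1.34 log units; beyond the scatter). Exchanging the whole aryl group gives an 11-fold lower number from compound 1 to compound 4 (1.04 log units; beyond the scatter), so compound 4 is the most potent of the four, with each of its steps beyond the scatter. Compound 2 and compound 3 each stand at a limit and not at a number, so the first two steps give only floors: the limit of > 128000 nM in this assay, at which 2 of the 4 values shown sit.

The compounds shown do not tell whether chloro, nitrile or an amine at this position would give a similar drop. They also give no cause for the change seen with fluoro.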